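Bromo in Place of Iodo: A Paired Comparison

The source may report more compounds than this note shows. Statements on the series, on what has been measured and on what is new or still open speak of the compounds shown alone.

Of the compounds shown here, three have been measured in an assay on membranes from brain (Cavia porcellus) for binding affinity to Sigma non-opioid intracellular receptor 1 (Homo sapiens); on this read-out lower numbers stand for stronger inhibition and higher numbers for weaker inhibition. Compound 1 `O=S(=O)(NCCN1CCCCCC1)c1ccc(I)cc1` gives 1.32 nM, the lowest of the three numbers. Compound 3 `CCN(CC)CCNS(=O)(=O)c1ccc(I)cc1` gives 4.97 nM, and compound 2 `CCN(CC)CCNS(=O)(=O)c1ccc(Br)cc1` gives 10.1 nM. The difference between the core of compound 1 and the core of compound 3 is not broken down here. Compound 2 differs from compound 3 in one place only, (bromo in place of iodo on an aromatic carbon), and that change brought a 2.0-fold higher number from compound 3 to compound 2 (0.31 log units; beyond the scatter), a modest step but beyond the scatter.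

Compound 4 `O=S(=O)(NCCN1CCCCCC1)c1ccc(Br)cc1` has not yet been measured in this assay . It differs from compound 1 by the same change, (bromo in place of iodo on an aromatic carbon), at the same place. Going by the values given here, since only one earlier instance of this change exists, the expectation rests on that single pair. Compound 4 is therefore expected to land at 2.6 nM, with a plausible range from 1.3 nM to 5.5 nM. This estimate means a step of a 2.0-fold higher number from compound 1 to compound 4 (0.29 log units; within the scatter), matching the size seen between compound 3 and compound 2, because of a 2.0-fold higher number from compound 3 to compound 2 (0.31 log units; beyond the scatter).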

Compound 4, inhibition constant: 0.63 nM
Beside the measured number, compound 4's estimate is 4.1-fold (0.62 log units) above it; measured number outside the range, below it.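

In this assay, bromo in place of iodo gave a 2.1-fold lower number from compound 1 to compound 4 (0.32 log units; beyond the scatter), so the direction of the change did not carry over from one core to the other. The two cores answer the same swap differently, and the gap between the two steps is larger than repeat measurements would explain: the same change on two cores in this assay, a 2.0-fold higher number (0.31 log units; beyond the scatter) from compound 3 to compound 2 and a 2.1-fold lower number (0.32 log units; beyond the scatter) from compound 1 to compound 4, 4.3-fold (0.63 log units) apart, beyond the scatter of two such steps

This shows that, in this series, the step seen on one core is no reliable guide to the step on the other, though it does not show why the two cores part ways, and one pair on each core cannot say which outcome is the more usual.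

The compounds shown leave open how the swap behaves with other amines at the chain end, such as a morpholine or a dimethylamino group, or with a longer chain leading to the amine. As far as these compounds go, it also remains open whether a chloro or fluoro group, para to a large group, would follow the bromo or the iodo compounds on each core.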